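The source may hold more compounds than are shown below. What is called first, only, known or untested is meant among the compounds shown, and "the series" means these compounds.

Working notes on the series. Of the compounds shown here, three have numbers so far, all on one shared core: compound 1 `CC(=O)c1cc(-c2ccccc2)cc2cc(-c3ccccc3)[nH]c12`, compound 2 `COc1ccc(-c2cc(C(C)=O)c3[nH]c(-c4ccccc4)cc3c2)cc1` and compound 3 `COc1ccc(-c2cc(C(C)=O)c3[nH]c(-c4ccc(OC)cc4)cc3c2)cc1`. In a functional assay on MCF7 cells (Homo sapiens) for cytotoxicity, read by MTT assay, with a stated time of 2 days, tested at 10 uM (on this read-out higher numbers stand for a weaker effect at the one concentration tested and lower numbers for a stronger effect), compound 1 gives 96.2%, compound 2 gives 49.5% and compound 3 gives 56.4%. Compound 2 holds the lowest of the three numbers; its nearest neighbour is compound 3, with a number 6.9 percentage points higher from compound 2 to compound 3 (within the scatter), and its furthest is compound 1, with a number 46.7 percentage points lower from compound 1 to compound 2 (beyond the scatter).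

Compound 4 `CC(=O)c1cc(/C=C/c2ccc(F)cc2)cc2cc(-c3ccccc3)[nH]c12` is not yet measured. Relative to compound 2 the change is 2-(4-fluorophenyl)ethenyl in place of 4-methoxyphenyl on an aromatic carbon.

Neither measured step exchanges a whole group of this kind; both concern a single methoxy. Among the measured compounds shown here, the one that bears most on the change is a number 46.7 percentage points lower from compound 1 to compound 2 (beyond the scatter), the only large step in the set, since the methoxy it introduced sits on the 4-methoxyphenyl that now leaves. The other, a number 6.9 percentage points higher from compound 2 to compound 3 (within the scatter), was within the scatter and adds little. As far as these compounds go, because the group entering in compound 4 carries no such methoxy, the expectation is a step back toward the number of compound 1, though the entering group itself is untested, so the range is kept wide. The expected step is a number 25.5 percentage points higher from compound 2 to compound 4 (beyond the scatter). For compound 4 the estimate in this assay is 75%, with a range from 45% to 100%.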

Compound 4, a percentage reported as activity, at one concentration (the size of the read-out at that concentration, not a potency): 46.5%
Estimate against measurement, compound 4: 28.5 percentage points above, and the stated range covers the measured number.
By their numbers in this assay, from the lowest: compounds 4, 2 and 3 (each within the scatter of the next); then compound 1.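

In this assay, the step of a number 3 percentage points lower from compound 2 to compound 4 (within the scatter) shows that 2-(4-fluorophenyl)ethenyl and 4-methoxyphenyl cannot be told apart on this aromatic carbon, meta to the acetyl group, although the entering group carries no methoxy and has 0 hydrogen-bond acceptors. Among the compounds shown here, the step of a number 49.7 percentage points lower from compound 1 to compound 4 (beyond the scatter) adds a second large step away from the phenyl compound, so at this position the stronger effect at the one concentration tested is no longer seen only with a methoxy-bearing group. Nothing on hand gives a reason for either step.

Whether the fluorine, the ethenyl link or the added distance of the ring from the core matters most stays open, as 4-fluorophenyl and unsubstituted 2-phenylethenyl are absent from the compounds shown. Also open, as far as these compounds go, is how a 4-aminophenyl group, a 4-carboxyphenyl group or a longer chain would read at this position, and whether these single-concentration numbers would hold up as a ranking of potency.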